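A Swap on the Ring Nitrogen, Awaiting a Number

The compounds below may be only part of what the source reports. "The series", "measured", "known", "first", "only" and "open" are said of these compounds alone.

Compound 1 `COc1ccccc1Nc1nc(-c2cccc(F)c2)nc2ccc(F)cc12` and compound 2 `Fc1cccc(-c2nc(Nc3cccc(Br)c3)c3cc(F)ccc3n2)c1` share one core and differ only at a nitrogen on an aromatic ring. In a functional assay on U-937 cells (Homo sapiens) for cytotoxicity, read by MTT assay, with a stated time of 48 h (a lower number here means a stronger inhibitor, a higher number a weaker inhibitor), compound 1 gives > 50000 nM, which is a limit of the assay. In this assay compound 2 gives > 50000 nM, also a limit. The step that the two limits leave unreadable from compound 1 to compound 2 therefore cannot be sized, since (the limit of > 50000 nM in this assay, at which 2 of the 2 values shown sit). Compound 3 `Nc1ccccc1Nc1nc(-c2cccc(F)c2)nc2ccc(F)cc12` differs from compound 2 by 2-aminophenyl in place of 3-bromophenyl on a nitrogen on an aromatic ring. For the measured compounds named here, no measured step bears on this change with a readable size. Compound 3 is expected to remain near the limit, an estimated 50000 nM within 15000 nM to 150000 nM, a step of a number no higher from compound 2 to compound 3 (the limit leaves the size open).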

Compound 3, half-maximal inhibitory concentration: 47300 nM
Compound 3: the middle estimate sits 1.1-fold (0.02 log units) above what was measured; low and high end bracket the measured number.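

In this assay, for the compounds shown here, compound 3 gives 47300 nM, the first number that is not a limit, so with 2-aminophenyl on this nitrogen the assay returns a reading. That gives an at least 1.0-fold lower number from compound 2 to compound 3 (0.02 log units; that floor lies within the scatter) and an at least 1.0-fold lower number from compound 1 to compound 3 (0.02 log units; that floor lies within the scatter), both only floors, so no real gain is shown. The true size of each step stays open because the other two compounds sit at a limit: the limit of > 50000 nM in this assay, at which 2 of the 3 values shown sit.

Going by these compounds, whether a dimethylamino group or a carboxylic acid in place of the amino group would give a clearly lower number remains open.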